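Amino group swaps and a silicon-bearing replacement

The source may report more compounds than this note shows. Statements on the series, on what has been measured and on what is new or still open speak of the compounds shown alone.

Values in a functional assay on SW480 cells (Homo sapiens) for antiproliferative activity, read by MTT assay, with a stated time of 48 h; on this read-out higher numbers stand for weaker inhibition and lower numbers for stronger inhibition:
- compound 1 `CC(C)=CCC[C@]1(C)/C=C/[C@@H](OC(=O)C=C(C)C)[C@](C)(O)/C=C/C(=O)/C(CN(C(C)C)C(C)C)=C\C1` gives 750 nM
- compound 2 `CC(C)=CCC[C@]1(C)/C=C/[C@@H](OC(=O)C=C(C)C)[C@](C)(O)/C=C/C(=O)/C(CN2CCCC2)=C\C1` gives 310 nM
- compound 3 `CC(C)=CCC[C@]1(C)/C=C/[C@@H](OC(=O)C=C(C)C)[C@](C)(O)/C=C/C(=O)/C(CN2CCN(C)CC2)=C\C1` gives 800 nM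

Compound 3 has the highest of the three numbers, but its gap to compound 1 lies within the scatter (a 1.1-fold higher number from compound 1 to compound 3 (0.03 log units; within the scatter)). Only compound 2 is separated from it (a 2.6-fold higher number from compound 2 to compound 3 (0.41 log units; beyond the scatter)).

The next analogue is compound 4 `CC[Si](CC)(CC)C/C1=C/C[C@](C)(CCC=C(C)C)/C=C/[C@@H](OC(=O)C=C(C)C)[C@](C)(O)/C=C/C1=O`, still unmeasured. On the saturated chain carbon bound to a double-bonded ring carbon, the change is a group of 7 heavy atoms (6 carbon, 1 silicon; no ring) in place of a group of 7 heavy atoms (5 carbon, 2 nitrogen; one six-membered non-aromatic ring with 2 hetero atoms), on a saturated chain carbon bound to a double-bonded ring carbon. The 4-methylpiperazin-1-yl group thus gives way to a group with no nitrogen and no ring.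

All measured steps at this place exchange one amino group for another. They are small: a 2.4-fold lower number from compound 1 to compound 2 (0.38 log units; beyond the scatter) is modest, as is the step to compound 3 from compound 2 noted above. Within the data shown here, no measured step replaces an amino group with a group lacking nitrogen, so the series gives only weak guidance here. The three values suggest no direction, and a change beyond the scatter cannot be predicted with confidence. The expected step is a 1.2-fold lower number from compound 3 to compound 4 (0.09 log units; within the scatter), and this estimate carries wide uncertainty. Compound 4 is expected at 650 nM (estimated range 200 nM to 2200 nM).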

Compound 4, half-maximal inhibitory concentration: 2690 nM
Estimate against measurement, compound 4: 4.1-fold (0.62 log units) below; the whole stated range lies below it.
By their numbers in this assay, from the lowest: compound 2; then compounds 1 and 3 (each within the scatter of the next); then compound 4.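

In this assay, among these compounds, the earlier steps at this position only exchanged one amino group for another, whereas removing the nitrogen raises the number against all three amino compounds (a 3.4-fold higher number from compound 3 to compound 4 (0.53 log units; beyond the scatter); a 3.6-fold higher number from compound 1 to compound 4 (0.55 log units; beyond the scatter); an 8.7-fold higher number from compound 2 to compound 4 (0.94 log units; beyond the scatter)). The step from the diisopropylamino group of compound 1 is the closest comparison, since both groups have the same heavy-atom count and no ring, so a ring is not what separates the silicon-bearing group from that amino group; even so, nitrogen on this saturated chain carbon is not needed for a measurable antiproliferative value, as compound 4 gives 2690 nM. No measurement shown gives a reason for this rise.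

The compounds shown leave open whether the rise follows from losing the nitrogen or from gaining the silicon, a question that an all-carbon counterpart with carbon in place of the silicon would separate. They also leave open how other cyclic amines, such as piperidin-1-yl or morpholin-4-yl, would stand against the pyrrolidin-1-yl group of compound 2.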